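This account rests on a few compounds, and the source may have more. Where it says the series, first, only, none or still open, it means among the compounds named here.

Measured compounds:
- compound 1 `Cn1ccc2cc(-c3cc4nccc(-c5ccc(F)cc5)n4n3)ccc21`, in a functional assay on B16-F0 cells (Mus musculus) for inhibition, read by CCK-8 assay, with a stated time of 48 h (a lower number here means a stronger inhibitor, a higher number a weaker inhibitor), compound 1 gives 4780 nM
- compound 2 `COc1cc(-c2ccnc3cc(-c4ccc5ccn(C)c5c4)nn23)cc(OC)c1OC`, compound 2 gives 657 nM
- compound 3 `COc1cc(-c2ccnc3cc(-c4ccc(-c5cnn(C)c5)cc4)nn23)cc(OC)c1OC`, compound 3 gives 1240 nM

Compound 2 has the lowest of the three numbers. Its gap to compound 3 lies within the scatter, so the two cannot be ordered; its gap to compound 1 lies beyond the scatter, so compound 2 is the stronger inhibitor of that pair.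

Compound 4 `COc1cc(-c2ccnc3cc(-c4cn(C)c5ccccc45)nn23)cc(OC)c1OC` is not yet measured. It keeps the shared core of compound 2 and differs in one place: 1-methyl-1H-indol-3-yl in place of 1-methyl-1H-indol-6-yl on an aromatic carbon. The two groups count the same atoms and rings; only the point of attachment of the 1-methylindole changes.

Among the compounds with values here, no pair of measured compounds shows a step of this kind, so the effect of the change is unknown from the data. The expectation is a small weakening in this assay, with a step from compound 2 to compound 4 of about a 2.0-fold higher number from compound 2 to compound 4 (0.30 log units; within the scatter), not clearly beyond the scatter. Compound 4 is estimated at 1300 nM, range 400 nM to 4500 nM.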

Compound 4, half-maximal inhibitory concentration: 185 nM
Compound 4: middle estimate off by 7.0-fold (0.85 log units), on the high side, and the stated range ends above it.
By their numbers in this assay, from the lowest: compound 4; then compounds 2 and 3 (each within the scatter of the next); then compound 1.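

In this assay, changing only the point of attachment of the 1-methylindole, from 1-methyl-1H-indol-6-yl to 1-methyl-1H-indol-3-yl, gives a 3.6-fold lower number from compound 2 to compound 4 (0.55 log units; beyond the scatter). The two groups have the same counts of atoms, rings, hydrogen-bond donors and acceptors, so this position on the shared core distinguishes between two attachments of one group, not only between different groups. Nothing at hand explains this difference.

Still open, on these data alone, is whether 1-methyl-1H-indol-3-yl brings a similar step on the core of compound 1, where the group on the other side of the core differs from that of compound 2. Also open, as far as these compounds go, is how the series responds when the methyl on the indole nitrogen gives way to a longer chain, such as a propyl chain, or to a chain ending in a carboxylic acid.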